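The source may hold more compounds than are shown below. What is called first, only, known or untested is meant among the compounds shown, and "the series" means these compounds.

Three compounds built on one shared core have been examined in an in vitro ADME assay on microsomes from liver (Homo sapiens) for pharmacokinetics, read by LC-MS, with a stated time of 10 min, tested at 1 uM; a higher number here means faster removal of the compound, a lower number slower removal. Compound 1 `CC(C)c1ccc(NC(=O)[C@H]2CN(C)C[C@@H]2c2ccc(/C=C/C(=O)Nc3ccccc3N)cc2)cc1` gives 10 mL/min/kg. Compound 2 `CN1C[C@H](C(=O)Nc2cccc(Cl)c2)[C@@H](c2ccc(/C=C/C(=O)Nc3ccccc3N)cc2)C1` gives 7 mL/min/kg. Compound 3 `CN1C[C@H](C(=O)NC2CC2)[C@@H](c2ccc(/C=C/C(=O)Nc3ccccc3N)cc2)C1` gives 10 mL/min/kg. On these numbers compound 1 sits level with compound 3, and the two together hold the highest figures of the three; its nearest neighbour is compound 3, its furthest compound 2, and every gap stays inside the usual scatter.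

Compound 4 `CN1C[C@H](C(=O)N2CCCCC2)[C@@H](c2ccc(/C=C/C(=O)Nc3ccccc3N)cc2)C1` is not yet measured. Compared with compound 1 it carries the change (piperidin-1-yl in place of (4-isopropylphenyl)amino on a carbonyl carbon). Among the measured compounds shown here, the steps that bear on this all exchange the group on the amide-type nitrogen: a 1.4-fold lower number from compound 1 to compound 2 (0.15 log units; within the scatter), no change at the digits printed from compound 1 to compound 3 (within the scatter) and a 1.4-fold higher number from compound 2 to compound 3 (0.15 log units; within the scatter). None of them shifted the number beyond the scatter, although none removed the amide hydrogen as the change to compound 4 does. On this evidence no step beyond the scatter is expected, and the estimated step is no change at the digits printed from compound 1 to compound 4 (within the scatter). For compound 4 the expected value is 10 mL/min/kg, with a range from 5 mL/min/kg to 20 mL/min/kg.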

Compound 4, clearance: 9 mL/min/kg
Estimate against measurement, compound 4: 1.1-fold (0.05 log units) above, and the stated range covers the measured number.
By their numbers in this assay, from the lowest: compounds 2, 4, 1 and 3 (each within the scatter of the next).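

Among the compounds shown here, compound 4 is the first here in which the group on the carbonyl carbon has no hydrogen-bond donor, since piperidin-1-yl leaves no amide hydrogen, and in this assay this still gives a 1.1-fold lower number from compound 1 to compound 4 (0.05 log units; within the scatter), along with a 1.1-fold lower number from compound 3 to compound 4 (0.05 log units; within the scatter) and a 1.3-fold higher number from compound 2 to compound 4 (0.11 log units; within the scatter). Among these four compounds, then, neither the amide hydrogen nor an aromatic ring in this group is needed for the number to stay within the scatter. Nothing available explains why the number holds so steady across these groups.

On these data alone, whether a morpholine ring or a piperidine bearing a primary amine at this carbonyl carbon would also stay within the scatter remains open, as does a carboxylic acid in place of the whole amide. All four compounds keep the rest of the shared core, so they say nothing about changes elsewhere.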